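The source may hold more compounds than are shown below. What is called first, only, known or untested is meant among the compounds shown, and "the series" means these compounds.

Working notes on the series in a functional assay, with a stated time of 10 min; on this read-out higher numbers stand for weaker inhibition and lower numbers for stronger inhibition. Compound 1 `O=c1cc(/C=C/c2ccccc2)[nH]cc1O` gives 4030 nM and compound 2 `O=c1cc(/C=C/c2ccc([N+](=O)[O-])cc2)[nH]cc1O` gives 4790 nM, so these two sit level. Compound 3 `COc1cc(/C=C/c2cc(=O)c(O)c[nH]2)cc(OC)c1` gives 11400 nM, a higher number than compound 2 shows. The next structure is compound 4 `O=c1cc(/C=C/c2ccc(O)cc2)[nH]cc1O`, reached from compound 2 by hydroxy in place of nitro on an aromatic carbon. Among the compounds with values here, the one measured step at this place is a 1.2-fold higher number from compound 1 to compound 2 (0.08 log units; within the scatter), with nitro in place of hydrogen on an aromatic carbon. Within the data shown here, no measured compound carries the entering hydroxy, so a step within the scatter is expected, with no direction favoured. For compound 4 the estimated value is 4500 nM, with an expected range of 1500 nM to 13000 nM. The expected step is a 1.1-fold lower number from compound 2 to compound 4 (0.03 log units; within the scatter).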

Compound 4, half-maximal inhibitory concentration: 1730 nM
Estimate against measurement, compound 4: 2.6-fold (0.42 log units) above; low and high end bracket the measured number.
By their numbers in this assay, from the lowest: compound 4; then compounds 1 and 2 (each within the scatter of the next); then compound 3.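

In this assay, hydroxy at this place gives a 2.8-fold lower number from compound 2 to compound 4 (0.44 log units; beyond the scatter) and a 2.3-fold lower number from compound 1 to compound 4 (0.37 log units; beyond the scatter), so the position does respond to the group it carries, which the nitro-for-hydrogen step within the scatter did not show. Hydroxy stands apart from both hydrogen and nitro, and those two sit level, so the series so far shows a response to this one group only. Nothing at hand explains the shift. As far as these compounds go, whether an amine or a carboxylic acid at the same place would match hydroxy stays open.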